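The compounds below may be only part of what the source reports. "The series", "measured", "known", "first", "only" and "open" are said of these compounds alone.

Compound 1 `COc1ccc(Cc2nc(-c3cc(Br)c(OCCCN(C)C)c(Br)c3)c[nH]c2=O)cc1Br`: 12200 nM
Compound 2 `CNCCCOc1c(Br)cc(-c2c[nH]c(=O)c(Cc3ccc(OC)c(Br)c3)n2)cc1Br`: 15400 nM

Compound 2 sits alongside compound 1 in a functional assay on A549 cells (Homo sapiens) for inhibition, read by MTT assay, with a stated time of 24 h (on this read-out lower numbers stand for stronger inhibition and higher numbers for weaker inhibition), separated from it only by a 1.3-fold higher number from compound 1 to compound 2 (0.10 log units; within the scatter), a step that lies within the scatter. Compound 3 `COc1ccc(Cc2nc(-c3cc(Br)c(O)c(Br)c3)c[nH]c2=O)cc1Br` shares the same core and differs from compound 2 by hydrogen in place of 3-(methylamino)propyl on an oxygen on an aromatic ring. Among the compounds with values here, the single measured step, from compound 1 to compound 2, alters the same chain and barely moves the read-out; no measured pair removes the chain altogether, so the size of the coming step is uncertain. Compound 3 is therefore expected close to compound 2, with a step of a 1.2-fold higher number from compound 2 to compound 3 (0.07 log units; within the scatter) and a wide range, estimated at 18000 nM between 6000 nM and 55000 nM.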

Compound 3, half-maximal inhibitory concentration: 52000 nM
For compound 3 the middle estimate is 2.9-fold (0.46 log units) below the measured one, and the stated range covers the measured number.
By their numbers in this assay, from the lowest: compounds 1 and 2 (each within the scatter of the next); then compound 3.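

Taking the whole chain off the oxygen on the aromatic ring, leaving hydroxy, registers in this assay as a 3.4-fold higher number from compound 2 to compound 3 (0.53 log units; beyond the scatter) and, for the loss of 3-(dimethylamino)propyl, as a 4.3-fold higher number from compound 1 to compound 3 (0.63 log units; beyond the scatter), whereas the change at the amine nitrogen stayed within the scatter. At this position, having the chain matters more than that methyl on its nitrogen. Nothing measured here explains the difference.

Going by these compounds, whether the amine or the carbon chain carries the step stays open. A propoxy group without nitrogen, or a longer chain ending in an amine, would separate the two.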